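A ring exchange on compound 3

This account rests on a few compounds, and the source may have more. Where it says the series, first, only, none or still open, it means among the compounds named here.

Measured in a functional assay (trachea) with Cavia porcellus as the target; on this read-out higher numbers stand for weaker inhibition and lower numbers for stronger inhibition:
Compound 1 `O=c1c2ccccc2c(-c2cccnc2)nn1CC1CCCCC1` gives 209 nM
Compound 2 `O=c1c2ccccc2c(-c2cccnc2)nn1CCSc1nccs1` gives 10500 nM
Compound 3 `CCn1nc(-n2ccnc2)c2ccccc2c1=O` gives 5370 nM

Compound 3 at 5370 nM lies within the scatter of compound 2 at 10500 nM, while compound 1 at 209 nM lies clearly beyond the scatter of compound 3, on the lower side. Compound 4 `CCn1nc(-c2cncs2)c2ccccc2c1=O` carries 1,3-thiazol-5-yl in place of 1H-imidazol-1-yl on an aromatic carbon. Within the data shown here, the only measured step, a 50-fold higher number from compound 1 to compound 2 (1.70 log units; beyond the scatter), is large but lies at a different place, so it shows only that numbers in this set can move far. Among the measured compounds shown here, no step at this aromatic carbon has been measured, so no shift beyond the scatter in this assay is expected, and no firm direction. The expected step is a 1.5-fold lower number from compound 3 to compound 4 (0.19 log units; within the scatter). Compound 4 is expected at 3500 nM, with an estimated range from 600 nM to 15000 nM.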

Compound 4, half-maximal inhibitory concentration: 562 nM
Estimate against measurement, compound 4: 6.2-fold (0.79 log units) above; measured number outside the range, below it.
By their numbers in this assay, from the lowest: compound 1; then compound 4; then compounds 3 and 2 (each within the scatter of the next).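

Among these compounds, this is the first measured change at the aromatic carbon next to the ring nitrogen, and in this assay it gives a 9.6-fold lower number from compound 3 to compound 4 (0.98 log units; beyond the scatter). So this position, not only the chain on the ring nitrogen, can move the number beyond the scatter, even though both groups are five-membered aromatic rings with equal counts of heavy atoms, donors and acceptors. No data on hand account for the difference between the two rings.

As far as these compounds go, it remains open how a plain phenyl ring or a dimethylamino group would compare at this carbon. From the compounds shown here alone, it is also open whether the step would hold with a longer chain in place of ethyl.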